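Thiosemicarbazone series: outlook for compound 3 in this assay

This account rests on a few compounds, and the source may have more. Where it says the series, first, only, none or still open, it means among the compounds named here.

Measured compounds:
compound 1 `CC1=CC[C@@H]([C@@](C)(O)CCCC(C)(C)NC(=S)N/N=C\c2cccc([N+](=O)[O-])c2)CC1`: 6720 nM
compound 2 `CC1=CC[C@@H]([C@@](C)(O)CCCC(C)(C)NC(=S)N/N=C\c2ccc([N+](=O)[O-])cc2)CC1`: 17700 nM

Both numbers come from a functional assay on MCF7 cells (Homo sapiens) for cytotoxicity, read by sulforhodamine B assay; a higher number here means a weaker inhibitor of growth, a lower number a stronger inhibitor of growth. Among the compounds with values here, compound 2 stands at the highest of the two values, the nearest being compound 1, with a 2.6-fold higher number from compound 1 to compound 2 (0.42 log units; beyond the scatter) marking the only step in the set. Compound 3 `CC1=CC[C@@H]([C@@](C)(O)CCCC(C)(C)NC(=S)N/N=C\c2ccccc2Cl)CC1` differs from compound 2 by 2-chlorophenyl in place of 4-nitrophenyl on a carbon with a double bond to nitrogen.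

Within the data shown here, no measured step exchanges the nitrophenyl for a chlorophenyl, so the change is untested here. Among the measured compounds shown here, the one step available, a 2.6-fold higher number from compound 1 to compound 2 (0.42 log units; beyond the scatter), shows that altering the substitution of this aromatic ring moves this assay by a modest amount, and a step of comparable size is expected for compound 3, with its direction uncertain. Since compound 2 holds the higher of the two numbers, the estimate leans towards a lower value.

Compound 3 is estimated at 10000 nM in this assay, with a range from 3000 nM to 35000 nM. The expected step is a 1.8-fold lower number from compound 2 to compound 3 (0.25 log units; within the scatter).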

Compound 3, concentration for 50% growth inhibition: 31200 nM
Compound 3: the middle estimate sits 3.1-fold (0.49 log units) below what was measured; the measured number falls inside the stated range.
By their numbers in this assay, from the lowest: compound 1; then compounds 2 and 3 (each within the scatter of the next).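

In this assay, 2-chlorophenyl in place of 4-nitrophenyl on a carbon with a double bond to nitrogen gives a step within the scatter (a 1.8-fold higher number from compound 2 to compound 3 (0.25 log units; within the scatter)), so compound 2 and compound 3 cannot be told apart and a nitro group is not required to reach this level. The same exchange made from 3-nitrophenyl gives a step beyond the scatter (a 4.6-fold higher number from compound 1 to compound 3 (0.67 log units; beyond the scatter)), which leaves compound 1, with steps beyond the scatter to both others, as the strongest inhibitor of growth of the three. Nothing available bears on why these steps have the sizes they do.

Both the group and its place on the aromatic ring differ between compound 3 and either nitro compound, so the contribution of each remains unseparated. Also open, going by these compounds, is how this assay responds to an amine or a carboxylic acid on that ring, or to a plain phenyl.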